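From tert-butyl to isopropyl: an expected small step

The source may hold more compounds than are shown below. What is called first, only, known or untested is meant among the compounds shown, and "the series" means these compounds.

Compound 1 `O=C(CCC1=CCN(CCCc2ccc(Cl)cc2)C1=O)NO` and compound 2 `CC(C)(C)c1ccc(CCCN2CC=C(CCC(=O)NO)C2=O)cc1` differ only by a tert-butyl in place of chloro on an aromatic carbon. In a functional assay on ACHN cells (Homo sapiens) for inhibition, read by sulforhodamine B assay (on this read-out lower numbers stand for stronger inhibition of growth and higher numbers for weaker inhibition of growth), compound 1 gives 3330 nM, and compound 2 gives 3330 nM, so the step of no change at the digits printed from compound 1 to compound 2 (within the scatter) stayed within the scatter; compound 2 thus stands level with compound 1. Compound 3 `CC(C)c1ccc(CCCN2CC=C(CCC(=O)NO)C2=O)cc1` carries hydrogen in place of methyl on a saturated chain carbon bound to an aromatic carbon and two saturated chain carbons. Among the compounds with values here, because the step of no change at the digits printed from compound 1 to compound 2 (within the scatter) showed no change, and no measured step removes a methyl at this place, compound 3 is expected to move by a 1.0-fold lower number from compound 2 to compound 3 (0.00 log units; within the scatter) in this assay. Compound 3 is therefore estimated at 3300 nM, between 1500 nM and 7500 nM.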

Compound 3, concentration for 50% growth inhibition: 3330 nM
Compound 3: middle estimate off by 1.0-fold (0.00 log units), on the low side; measured number inside the range.
By their numbers in this assay, from the lowest: compounds 1, 2 and 3 (each within the scatter of the next).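

Cutting tert-butyl to isopropyl gives no change at the digits printed from compound 2 to compound 3 (within the scatter) in this assay, and isopropyl in place of chloro on an aromatic carbon gives no change at the digits printed from compound 1 to compound 3 (within the scatter). A third group at this place thus reads level with the other two, so among these compounds the size of the branched group shows no effect on the number. Nothing at hand accounts for this flat result.

On these data alone, whether an amine or a carboxylic acid at this place would read the same stays open, as does the effect of changes elsewhere on the shared core.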